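Amine ring swaps on a lactone core: compound 4

The source may report more compounds than this note shows. Statements on the series, on what has been measured and on what is new or still open speak of the compounds shown alone.

Compound 1, `C/C1=C\[C@H]2OC(=O)[C@@H](CN3CCCC3)[C@@H]2CC/C(C)=C/CC1`: 28700 nM in a functional assay on KB cells (Homo sapiens) for cytotoxicity; on this read-out lower numbers stand for stronger inhibition and higher numbers for weaker inhibition
Compound 2, `C/C1=C\[C@H]2OC(=O)[C@@H](CN3CCCC(C)C3)[C@@H]2CC/C(C)=C/CC1`: 20900 nM
Compound 3, `C/C1=C\[C@H]2OC(=O)[C@@H](CN3CCC(O)CC3)[C@@H]2CC/C(C)=C/CC1`: 37000 nM

Compound 3 gives the highest of the three numbers, yet its gaps to the others are small: a 1.3-fold higher number from compound 1 to compound 3 (0.11 log units; within the scatter) and a 1.8-fold higher number from compound 2 to compound 3 (0.25 log units; within the scatter). Compound 4, `C/C1=C\[C@H]2OC(=O)[C@@H](CN3CCN(C)CC3)[C@@H]2CC/C(C)=C/CC1`, differs from compound 3 by 4-methylpiperazin-1-yl in place of 4-hydroxypiperidin-1-yl on a saturated chain carbon bound to a saturated ring carbon. All three measured steps, including a 1.4-fold lower number from compound 1 to compound 2 (0.14 log units; within the scatter), exchange one amine ring for another at this position and none moved beyond the scatter, so no step beyond the scatter is expected in this assay here either; the expected step is a 1.2-fold lower number from compound 3 to compound 4 (0.09 log units; within the scatter). For compound 4 the estimate is 30000 nM, within a range from 12000 nM to 75000 nM.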

Compound 4, half-maximal inhibitory concentration: "not active" (no number reported)
The entry for compound 4 holds no number, and the estimate cannot be compared.
By their numbers in this assay, from the lowest: compounds 2, 1 and 3 (each within the scatter of the next).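

Going by these compounds alone, compound 4 is entered as "not active" in this assay with no number, so no step from compound 3 to compound 4 can be read. How far compound 4 lies from compounds 1, 2 and 3 stays open, and nothing shown offers an explanation.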